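The compounds below may be only part of what the source reports. "The series", "measured", "known", "first", "only" and "open" are said of these compounds alone.

Measured compounds in a functional assay on the whole organism for antagonist activity, with Mus musculus as the target; a higher number here means that more compound is needed for the effect, a lower number that less compound is needed:
compound 1, `CCCCCCCN1CCC(C(=O)Nc2cc(Cl)c(N)cc2OC)CC1`, a limit only: > 10 mg/kg
compound 2, `COc1cc(N)c(Cl)cc1NC(=O)C1CCN(Cc2ccccc2Cl)CC1`, a limit only: > 4 mg/kg
compound 3, `COc1cc(N)c(Cl)cc1NC(=O)C1CCN(Cc2ccc(Cl)cc2)CC1`: 1.2 mg/kg

Compound 1 stands only at a limit in this assay, not at a number (the limit of > 10 mg/kg in this assay, at which 1 of the 3 values shown sits). Compound 2 is likewise a limit (the limit of > 4 mg/kg in this assay, at which 1 of the 3 values shown sits). Compound 3 alone carries a number.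

Compound 4 is `COc1cc(N)c(Cl)cc1NC(=O)C1CCN(Cc2cccc(C#N)c2)CC1`. Its change from compound 1 is 3-cyanophenyl in place of hexyl on a saturated chain carbon bound to an amine nitrogen in a ring. Two measured steps share the same place: an at least 8.3-fold lower number from compound 1 to compound 3 (0.92 log units; beyond the scatter), at least modest, and a step that the two limits leave unreadable from compound 1 to compound 2, which the two limits leave unreadable. Among the aryl groups themselves, an at least 3.3-fold lower number from compound 2 to compound 3 (0.52 log units; beyond the scatter) shows that the position of the chlorine changes the outcome beyond the scatter. Among the measured compounds shown here, an aromatic ring in place of hexyl is thus read as lowering the number, but the 3-cyanophenyl carries its substituent at a position with no measured counterpart here, so the size is uncertain. Compound 4 is estimated at 2.5 mg/kg, in the range 0.8 mg/kg to 8 mg/kg. This estimate means an expected at least 4.0-fold lower number from compound 1 to compound 4 (0.60 log units; beyond the scatter).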

Compound 4, dose for half-maximal effect: > 4 mg/kg
Compound 4 ended at the assay's limit; the forecaster's own chance of this, stated with the estimate: 25%; middle value at least 1.6-fold (0.20 log units) away from the limit.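

In this assay compound 4 stands at a limit, not at a number: the limit of > 4 mg/kg in this assay, at which 2 of the 4 values shown sit. Among the compounds shown here, the one readable step is an at least 3.3-fold higher number from compound 3 to compound 4 (0.52 log units; beyond the scatter), so at this place 3-cyanophenyl does not match 4-chlorophenyl, and an aromatic ring in place of hexyl does not by itself give a measured number. Of the aryl compounds, compound 3 alone carries a number, while compound 2 and compound 4 both remain at limits, and the steps from compound 1 and from compound 2 to compound 4 cannot be read.

Going by these compounds, what remains open is whether the nitrile itself or its place on the ring sets this outcome. A 4-cyanophenyl or a 3-chlorophenyl group on the same chain carbon would separate these two readings.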